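Ethoxy for Methyl in a Chalcone Amide Series on Vero Cells

The source may hold more compounds than are shown below. What is called first, only, known or untested is meant among the compounds shown, and "the series" means these compounds.

Compound 1 `COC(=O)c1cc(-c2cccc(NC(=O)c3ccc(/C=C/C(=O)c4cccs4)cc3)c2)on1`: "not determined" (no result reported) in an ADME assay on Vero cells (Chlorocebus sabaeus) for cytotoxicity, read by MTT assay, with a stated time of 72 h; on this read-out lower numbers stand for higher toxicity in this test and higher numbers for lower toxicity in this test.
Compound 2 `COC(=O)c1cc(-c2cccc(NC(=O)c3ccc(/C=C/C(=O)c4cc(F)ccc4F)cc3)c2)on1`: > 40 ug/mL in this assay, a limit of the assay.
Compound 3 `COC(=O)c1cc(-c2cccc(NC(=O)c3ccc(/C=C/C(=O)c4ccc(C)cc4)cc3)c2)on1`: > 80 ug/mL in this assay, a limit of the assay.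

Compound 3 therefore stands only at a limit in this assay, as does compound 2, while compound 1 has no result. Going by the values given here, the one step between measured compounds, a step that the two limits leave unreadable from compound 2 to compound 3, is left unreadable because both ends are limits (the limit of > 40 ug/mL in this assay, at which 1 of the 3 values shown sits, (the limit of > 80 ug/mL in this assay, at which 1 of the 3 values shown sits)). Compound 4 `CCOc1ccc(C(=O)/C=C/c2ccc(C(=O)Nc3cccc(-c4cc(C(=O)OC)no4)c3)cc2)cc1` differs from compound 3 by ethoxy in place of methyl on an aromatic carbon. Among the compounds with values here, no measured step bears on this change, so no shift beyond the scatter is expected in this assay, and the step of a number no higher from compound 3 to compound 4 (the limit leaves the size open) is an estimate of no real change. Compound 4 is expected to give about 80 ug/mL, within 40 ug/mL to 160 ug/mL, most likely again as a limit.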

Compound 4, half-maximal cytotoxic concentration: > 40 ug/mL
Compound 4 was reported as a limit; the forecaster's own chance of this, stated with the estimate: 70%; the middle value does not contradict the limit.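

Compound 4 gives only a limit in this assay, as do compound 2 and compound 3, so no step among these three compounds can be read. The compounds shown leave open whether ethoxy in place of methyl changes the half-maximal cytotoxic concentration at all.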